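This account rests on a few compounds, and the source may have more. Where it says the series, first, only, none or still open, it means among the compounds named here.

Working notes on the series in an ADME assay on BaF3 cells (Mus musculus) for cytotoxicity; a higher number here means that more compound is needed for the effect, a lower number that less compound is needed. Compound 1 (`CC(=O)Nc1nc2ccc(-c3cccc(C(=O)Nc4cccc(C(F)(F)F)c4)c3)nc2s1`) gives > 10000 nM, which is a limit of the assay and not a number. Compound 2 (`CCN1CCN(Cc2ccc(NC(=O)c3cccc(-c4ccc5nc(N)sc5n4)c3)cc2C(F)(F)F)CC1`) gives > 10000 nM, again a limit. Going by the values given here, compound 3 (`CCN1CCN(Cc2ccc(NC(=O)c3cccc(-c4ccc5nc(NC(C)=O)sc5n4)c3)cc2C(F)(F)F)CC1`) gives 4160 nM, the only true number so far.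

Compound 4 (`CCN1CCN(Cc2ccc(NC(=O)c3cccc(-c4ccc5nc(Nc6ccccn6)sc5n4)c3)cc2C(F)(F)F)CC1`) carries pyridin-2-yl in place of acetyl on a nitrogen on an aromatic ring. The nearest evidence is an at least 2.4-fold lower number from compound 2 to compound 3 (0.38 log units; beyond the scatter), which acts at that same nitrogen but is only a bound, since one end is a limit. The other measured step, an at least 2.4-fold lower number from compound 1 to compound 3 (0.38 log units; beyond the scatter), concerns the (4-ethylpiperazin-1-yl)methyl group, which compound 4 keeps, so it bears on the change only indirectly. Among the compounds with values here, no measured pair exchanges acetyl for another group at this nitrogen, so no direction can be read from the data, and no shift beyond the scatter is expected in this assay. The expected change is a 1.0-fold lower number from compound 3 to compound 4 (0.02 log units; within the scatter). For compound 4 the estimated value is 4000 nM, with an expected range of 1300 nM to 10000 nM.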

Compound 4, half-maximal effective concentration: 3530 nM
Beside the measured number, compound 4's estimate is 1.1-fold (0.05 log units) above it, within the range that was stated.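

In this assay, this nitrogen now has a measured exchange of one substituent for another: pyridin-2-yl in place of acetyl gives a 1.2-fold lower number from compound 3 to compound 4 (0.07 log units; within the scatter), so the ring and the acyl group cannot be told apart here. Pyridin-2-yl in place of hydrogen gives an at least 2.8-fold lower number from compound 2 to compound 4 (0.45 log units; beyond the scatter), in the same direction as acetyl in an at least 2.4-fold lower number from compound 2 to compound 3 (0.38 log units; beyond the scatter), so in compounds 3 and 4 both substituents on this nitrogen go with a number that is measured and not a limit. Compound 2 stands at a limit and not a number, so both of these steps are bounds and not sizes: the limit of > 10000 nM in this assay, at which 2 of the 4 values shown sit.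

Going by these compounds, whether a longer chain, a carboxylic acid or a saturated amine on this nitrogen would also stay within the scatter of compound 3 remains open. Also open, on these data alone, is whether the (4-ethylpiperazin-1-yl)methyl group counts for as much alongside pyridin-2-yl as it does alongside acetyl.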